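Swapping Methyl for Phenyl on an Aziridine-Bearing Quinone

This account rests on a few compounds, and the source may have more. Where it says the series, first, only, none or still open, it means among the compounds named here.

Compound 3 `Cc1ccc2c(n1)C(=O)C=C(N1CC1)C2=O` gives the lowest number of the three compounds measured in a functional assay on NCI60 cells (Homo sapiens) for cytotoxicity; a lower number here means a stronger inhibitor of growth, a higher number a weaker inhibitor of growth: compound 3 gives 513 nM. Compound 2 `COCCCNC1=CC(=O)c2ccc(-c3ccccc3)nc2C1=O` gives 5500 nM, and compound 1 `O=C1C=C(NCc2ccccc2)C(=O)c2nc(-c3ccccc3)ccc21` gives 33100 nM, both far above compound 3 and beyond the scatter. Among the compounds with values here, the only measured step, a 6.0-fold lower number from compound 1 to compound 2 (0.78 log units; beyond the scatter), concerns the group attached to the amine nitrogen, not the group whose exchange is at issue here. Compound 4 `O=C1C(N2CC2)=CC(=O)c2nc(-c3ccccc3)ccc21` differs from compound 3 in one place: phenyl in place of methyl on an aromatic carbon. Within the data shown here, no measured pair shows this exchange on its own, so its direction cannot be read from the data. Compounds 1 and 2 do carry the phenyl, but they also carry a different amine, and their much higher numbers cannot be attributed to the phenyl alone. The step of a 1.6-fold higher number from compound 3 to compound 4 (0.19 log units; within the scatter) is therefore expected to be modest in size and uncertain in direction. Compound 4 is estimated at 800 nM, within 200 nM to 3000 nM.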

Compound 4, concentration for 50% growth inhibition: 27.5 nM
Estimate against measurement, compound 4: 29-fold (1.46 log units) above; measured number outside the range, below it.
By their numbers in this assay, from the lowest: compound 4; then compound 3; then compound 2; then compound 1.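

In this assay, within the data shown here, phenyl in place of methyl on this aromatic carbon, next to the ring nitrogen, gives a 19-fold lower number from compound 3 to compound 4 (1.27 log units; beyond the scatter), the first reading of this exchange with the aziridine kept the same. The phenyl therefore does not rule out a low number: compound 1 and compound 2 carry it too, and they differ from compound 4 in the amine group on the shared core. No evidence on why this exchange lowers the number is at hand.

From the compounds shown here alone, whether an ethyl chain, a pyridine ring or a phenyl bearing a methoxy group on this carbon would give a number nearer that of compound 3 or compound 4 remains open. Also open, going by these compounds, is whether the same exchange would shift the number to a similar extent with the amine groups of compound 1 and compound 2.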